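A few compounds are considered here, and "the series" means these few. Any claim that something is new, unique, unknown or untested is made for them only; others in the source may bear on it.

Compound 3 `O=C1c2ccccc2S(=O)(=O)N1CCCCCCN1CCN(c2cccc3ccccc23)CC1` gives 157 nM in an ADME assay on HEK293 cells for displacement of a labelled ligand from 5-hydroxytryptamine receptor 6 (Homo sapiens), read by radioligand binding, with a stated time of 1 h (on this read-out lower numbers stand for stronger inhibition and higher numbers for weaker inhibition), the lowest number of the three compounds measured. Compound 1 `O=C1c2ccccc2S(=O)(=O)N1CCCCCCN1CCN(c2cccc(Cl)c2)CC1` gives 372 nM in this assay, and compound 2 `COc1cccc(N2CCN(CCCCCCN3C(=O)c4ccccc4S3(=O)=O)CC2)c1` gives 921 nM. Compound 4 `O=C1c2ccccc2S(=O)(=O)N1CCCCCCN1CCN(c2ccccn2)CC1` differs from compound 3 by pyridin-2-yl in place of naphthalen-1-yl on an amine nitrogen in a ring. For the measured compounds named here, the steps that bear on this change are those at the same position: a 2.4-fold lower number from compound 1 to compound 3 (0.37 log units; beyond the scatter) and a 5.9-fold lower number from compound 2 to compound 3 (0.77 log units; beyond the scatter), both modest and both ending at the naphthalen-1-yl of compound 3. The group entering in compound 4 is not covered by any measured step, so a modest rise in the number is expected, most likely beyond the scatter. Compound 4 is estimated at 600 nM, within 150 nM to 2500 nM, an expected step of a 3.8-fold higher number from compound 3 to compound 4 (0.58 log units; beyond the scatter).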

Compound 4, inhibition constant: 2350 nM
For compound 4 the middle estimate is 3.9-fold (0.59 log units) below the measured one; the measured number falls inside the stated range.
By their numbers in this assay, from the lowest: compound 3; then compound 1; then compound 2; then compound 4.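

In this assay, for the compounds shown here, pyridin-2-yl gives the highest number of the four compounds, with a 15-fold higher number from compound 3 to compound 4 (1.18 log units; beyond the scatter) as the only large step at this position. The same group also falls behind both phenyl compounds, with a 6.3-fold higher number from compound 1 to compound 4 (0.80 log units; beyond the scatter) and a 2.6-fold higher number from compound 2 to compound 4 (0.41 log units; beyond the scatter) as the two steps. No measured evidence accounts for this change. The compounds shown leave open where an unsubstituted phenyl group would fall, and so whether the step follows the ring nitrogen or the loss of the second aromatic ring.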